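The source may hold more compounds than are shown below. What is called first, only, known or untested is meant among the compounds shown, and "the series" means these compounds.

Working notes on the series. Compound 1 `COc1ccc(/C=C2\CN(Cc3cn(Cc4ccc(F)cc4)nn3)C/C(=C\c3ccc(OC)cc3)C2=O)cc1`, compound 2 `O=C1/C(=C/c2ccccc2F)CN(Cc2cn(Cc3ccccc3Cl)nn2)C/C1=C\c1ccccc1F` and compound 3 `COc1ccc(/C=C2\CN(Cc3cn(Cc4ccccc4Cl)nn3)C/C(=C\c3ccc(OC)cc3)C2=O)cc1` have been tested in a functional assay on MCF7 cells (Homo sapiens) for cytotoxicity, read by MTT assay, with a stated time of 24 h; a lower number here means a stronger inhibitor, a higher number a weaker inhibitor. For compound 1 the result is a limit of the assay, > 100000 nM. For compound 3 the result is likewise a limit, > 100000 nM. Among the measured compounds shown here, compound 2 is the only one with a number and gives 10000 nM. The difference between the core of compound 2 and that of compound 3 is not broken down here.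

The change 4-fluorophenyl in place of 2-chlorophenyl on a saturated chain carbon bound to an aromatic nitrogen gives a step that the two limits leave unreadable from compound 3 to compound 1, because of the limit of > 100000 nM in this assay, at which 2 of the 3 values shown sit, the size cannot be read. The same change, (4-fluorophenyl in place of 2-chlorophenyl on a saturated chain carbon bound to an aromatic nitrogen), leads to compound 4 `O=C1/C(=C/c2ccccc2F)CN(Cc2cn(Cc3ccc(F)cc3)nn2)C/C1=C\c1ccccc1F`, not yet measured.

With the earlier step unreadable, no direction is expected; compound 4 is estimated to sit near compound 2, with an expected step of a 1.5-fold higher number from compound 2 to compound 4 (0.18 log units; within the scatter). The estimate for compound 4 in this assay is 15000 nM, expected between 4000 nM and 70000 nM.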

Compound 4, half-maximal inhibitory concentration: 6000 nM
For compound 4 the middle estimate is 2.5-fold (0.40 log units) above the measured one; low and high end bracket the measured number.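

In this assay, 4-fluorophenyl in place of 2-chlorophenyl gives a 1.7-fold lower number from compound 2 to compound 4 (0.22 log units; within the scatter). On the core of compound 2, the change therefore cannot be told apart from the usual scatter. Whether this result carries over to the core of compound 3 is not shown, since the matching step from compound 3 to compound 1 cannot be read, the reason being an assay limit: the limit of > 100000 nM in this assay, at which 2 of the 4 values shown sit.

The compounds shown leave open how a plain benzyl, a longer chain, or a benzyl carrying an amine or a carboxylic acid would read at this place on either core. They also leave open whether the change reads alike on two cores when all the values are numbers rather than limits.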